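The source may report more compounds than this note shows. Statements on the series, on what has been measured and on what is new or still open speak of the compounds shown alone.

Measured in a functional assay on HT-29 cells (Homo sapiens) for antiproliferative activity, read by sulforhodamine B assay, with a stated time of 48 h; on this read-out higher numbers stand for weaker inhibition and lower numbers for stronger inhibition:
Compound 1 `O=C1NCCN1c1ccc(S(=O)(=O)Nc2ccccc2)cc1`: 280 nM
Compound 2 `O=C1NCCN1c1ccc(S(=O)(=O)Nc2ccc(Br)cc2)cc1`: 300 nM
Not yet measured:
Compound 3 `Cc1ccccc1NS(=O)(=O)c1ccc(N2CCNC2=O)cc1`

Among the measured compounds shown here, only two numbers exist so far, and they cannot be told apart. For the measured compounds named here, the single step between them is a 1.1-fold higher number from compound 1 to compound 2 (0.03 log units; within the scatter), so compound 2 stands level with its only neighbour. That step put bromo in place of hydrogen on an aromatic carbon, and it left the number within the scatter.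

The next structure, compound 3, carries 2-methylphenyl in place of 4-bromophenyl on a sulfonamide nitrogen. The shared core stays as it was. Going by the values given here, the bromo group goes, and the one measured step gives no sign that it matters here. Among the compounds with values here, no measured compound, however, tests a methyl group, so this guide is thin and the range must stay wide.

With so little evidence, no shift beyond the scatter is expected, and the estimate is a 1.2-fold lower number from compound 2 to compound 3 (0.08 log units; within the scatter). For compound 3 the expected value is 250 nM, with an estimated range from 80 nM to 800 nM.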

Compound 3, half-maximal inhibitory concentration: 200 nM
For compound 3 the middle estimate is 1.3-fold (0.10 log units) above the measured one; the range from low to high includes it.
By their numbers in this assay, from the lowest: compounds 3, 1 and 2 (each within the scatter of the next).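

In this assay the sulfonamide nitrogen now carries a third group, and exchanging 4-bromophenyl for 2-methylphenyl gives a 1.5-fold lower number from compound 2 to compound 3 (0.18 log units; within the scatter), a step that stays within the usual scatter. Among the compounds shown here, the comparison with compound 1 is the first test of a methyl group on the aromatic ring, and methyl in place of hydrogen gives a 1.4-fold lower number from compound 1 to compound 3 (0.15 log units; within the scatter), which is also within the scatter. Across these three compounds, then, neither bromo nor methyl separates a substituted ring from the plain phenyl of compound 1, and no measurement at hand explains why these changes leave the number so little altered.

As far as these compounds go, all three groups on the sulfonamide nitrogen are six-membered aromatic rings of carbon only, so it remains open whether a pyridine ring, a saturated cyclohexyl ring or a simple ethyl chain would keep the number at this level. Also open, from the compounds shown here alone, is whether a hydroxy, methoxy or carboxylic acid group on the ring, or any change to the shared core, would produce a step beyond the scatter.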